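The compounds below may be only part of what the source reports. "The series", "measured", "known", "first", "only" and "open" are said of these compounds alone.

For the measured compounds named here, compound 2 `O=C(CSc1nnc(-c2ccncc2)n1-c1ccccc1)N/N=C/c1ccc(Cl)cc1` is, in a functional assay on HepG2 cells (Homo sapiens) for inhibition, read by MTT assay, with a stated time of 48 h (a lower number here means a stronger inhibitor, a higher number a weaker inhibitor), the weaker of the two compounds measured so far, giving 11000 nM. Its closest neighbour is compound 1 `O=C(CSc1nnc(-c2ccncc2)n1-c1ccccc1)N/N=C/c1ccc(Br)cc1`, which in this assay gives 5990 nM; the step of a 1.8-fold higher number from compound 1 to compound 2 (0.26 log units; within the scatter) is within the scatter, so the two compounds are not distinguished by the numbers. Compound 3 `O=C(CSc1nnc(-c2ccncc2)n1-c1ccccc1)N/N=C/c1ccccc1F` has not yet been measured. It differs from compound 2 in one place: 2-fluorophenyl in place of 4-chlorophenyl on a carbon with a double bond to nitrogen. Going by the values given here, the only measured step, a 1.8-fold higher number from compound 1 to compound 2 (0.26 log units; within the scatter), exchanges one halogen for another at the same position and is within the scatter; no measured step moves a substituent to a different position of that ring, so the data give no direction for such a change. For this reason compound 3 is expected to stay close to compound 2, with an expected step of a 1.1-fold lower number from compound 2 to compound 3 (0.04 log units; within the scatter) that does not exceed the scatter. The estimate for compound 3 in this assay is 10000 nM, with a range from 3500 nM to 30000 nM.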

Compound 3, half-maximal inhibitory concentration: 15200 nM
The estimate for compound 3 lay 1.5-fold (0.18 log units) below the measured number, and the stated range covers the measured number.
By their numbers in this assay, from the lowest: compounds 1, 2 and 3 (each within the scatter of the next, the first and the last beyond it).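

With 2-fluorophenyl in place of 4-chlorophenyl on the carbon with a double bond to nitrogen, the result is a 1.4-fold higher number from compound 2 to compound 3 (0.14 log units; within the scatter), so this change of both halogen and ring position does not separate the two compounds. For the compounds shown here, with 2-fluorophenyl in place of 4-bromophenyl at the same carbon, the result is a 2.5-fold higher number from compound 1 to compound 3 (0.40 log units; beyond the scatter), the first step in this set to pass the scatter, though only modestly. Nothing given here bears on the reason for either step.

In both steps the halogen and its place on the ring change together, so the numbers do not show which of the two counts. From the compounds shown here alone, how an amine or a carboxylic acid on this phenyl ring would behave in this assay remains open, as does a phenyl ring carrying no halogen.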